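Adding a second chloro to the aryl ketone of compound 3

The compounds below may be only part of what the source reports. "The series", "measured", "known", "first", "only" and "open" are said of these compounds alone.

Of the compounds shown here, three sharing one core have been tested in a functional assay on the whole organism for inhibition, with Mus musculus as the target, with a stated time of 1 h, at a dose of 30 mg/kg by the intraperitoneal route; on this read-out lower numbers stand for less inhibition and higher numbers for more inhibition at the one dose given (going by the name of the read-out). Compound 1 `O=C(/C=C/C1=Cc2ccccc2OC1)c1cccc(F)c1` gives 52.4%, compound 2 `O=C(/C=C/C1=Cc2ccccc2OC1)c1ccc(F)cc1` gives 65.6%, and compound 3 `O=C(/C=C/C1=Cc2ccccc2OC1)c1ccccc1Cl` gives 52.3%. Compound 3 thus sits lowest of the three numbers, though a number 0.1 percentage points lower from compound 1 to compound 3 (within the scatter) shows it is indistinguishable from compound 1, while a number 13.3 percentage points lower from compound 2 to compound 3 (beyond the scatter) places it clearly below compound 2. Among the compounds with values here, the only step that stood out, a number 13.2 percentage points higher from compound 1 to compound 2 (beyond the scatter), came from moving a fluoro from one position of the ring on the carbonyl carbon to another.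

Compound 4 `O=C(/C=C/C1=Cc2ccccc2OC1)c1ccc(Cl)cc1Cl` differs from compound 3 in one place: chloro in place of hydrogen on an aromatic carbon. Within the data shown here, no measured step adds a second halogen to a ring that already carries one, so there is nothing directly comparable. The measured steps show that rearranging a single halogen changes the read-out by at most a modest amount, and that swapping a 3-fluorophenyl for a 2-chlorophenyl changes nothing beyond the scatter. On that basis the change from compound 3 to compound 4 is expected to be small, a number 2.7 percentage points higher from compound 3 to compound 4 (within the scatter), with no clear direction. Compound 4 is therefore estimated at 55%, within a range from 38% to 72% in this assay.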

Compound 4, a percentage reported as inhibition, in the whole organism at one dose (the size of the read-out at that dose, not a potency): 53.3%
Estimate against measurement, compound 4: 1.7 percentage points above; the measured number falls inside the stated range.
By their numbers in this assay, from the lowest: compounds 3, 1 and 4 (each within the scatter of the next); then compound 2.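

On the aromatic ring of compound 3, a chloro enters at the place para to a large group and meta to the chloro group already there, and this gives a number 1 percentage points higher from compound 3 to compound 4 (within the scatter) in this assay. The earlier steps shown here only moved a halogen or exchanged one for another, whereas this one adds a second halogen to a ring that already carries one. At this position, the extra chloro leaves the read-out within the usual scatter of repeated measurements, so a ring with two chloro groups holds the same level of inhibition at the one dose given as the ring with a single chloro, and nothing shown here explains this outcome.

As far as these compounds go, what remains open is whether this position accepts only a small halogen or also a different kind of group, such as a methoxy group, an amine or a carboxylic acid, and whether any of these would shift the read-out beyond the scatter. From the compounds shown here alone, because the read-out is a single-dose percentage, it also remains open whether the added chloro would matter at other doses or at other times after dosing.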